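The source may hold more compounds than are shown below. What is called first, only, known or untested is meant among the compounds shown, and "the series" means these compounds.

Within the data shown here, in a functional assay on PC-3 cells (Homo sapiens) for cytotoxicity, read by MTT assay, with a stated time of 72 h (on this read-out higher numbers stand for weaker inhibition and lower numbers for stronger inhibition), compound 1 (`C=C1C2=C(C(=O)N1OC)[C@H](OC(=O)CSc1nc3ccccc3o1)[C@@](C)(O)[C@H](CCCCC)O2`) gives 5800 nM and compound 2 (`C=C1C2=C(C(=O)N1OC)[C@H](OC(=O)CCCCCl)[C@@](C)(O)[C@H](CCCCC)O2`) gives 9200 nM, so compound 2 stands within the scatter of the only other measured value. Compound 3 (`C=C1C2=C(C(=O)N1OC)[C@H](OC(=O)CSc1nc3ccccc3[nH]1)[C@@](C)(O)[C@H](CCCCC)O2`) has not yet been measured. It carries (1H-benzimidazol-2-yl)sulfanyl in place of 3-chloropropyl on a saturated chain carbon bound to a carbonyl carbon. Among the measured compounds shown here, one measured step bears on this change: a 1.6-fold higher number from compound 1 to compound 2 (0.20 log units; within the scatter). It exchanges (1,3-benzoxazol-2-yl)sulfanyl for the same 3-chloropropyl at the same place, and it stays within the scatter. For the measured compounds named here, no measured compound carries the entering group itself, so this evidence is thin. In this assay, the expectation is therefore no change beyond the scatter, and the estimate is a 1.4-fold lower number from compound 2 to compound 3 (0.15 log units; within the scatter). The estimated value for compound 3 is 6500 nM, with an expected range of 2500 nM to 15000 nM.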

Compound 3, half-maximal inhibitory concentration: 6400 nM
Estimate against measurement, compound 3: 1.0-fold (0.01 log units) above; measured number inside the range.
By their numbers in this assay, from the lowest: compounds 1, 3 and 2 (each within the scatter of the next).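

In this assay, replacing 3-chloropropyl with a second sulfur-linked bicyclic group gives a 1.4-fold lower number from compound 2 to compound 3 (0.16 log units; within the scatter) and so confirms, with the entering group itself, that this place on a saturated chain carbon bound to a carbonyl carbon tolerates such an exchange without a change beyond the scatter. Among these compounds, the first direct comparison of the two sulfur-linked groups, 1H-benzimidazol-2-yl in place of 1,3-benzoxazol-2-yl on a sulfur, gives a 1.1-fold higher number from compound 1 to compound 3 (0.04 log units; within the scatter) and likewise shows no separation between them. No measurement on hand accounts for why the three groups read alike. From the compounds shown here alone, whether an amine, a carboxylic acid or a longer chain at this place would move the number beyond the scatter remains open. So does the effect of a plain phenyl ring on the sulfur.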